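The source may report more compounds than this note shows. Statements on the series, on what has been measured and on what is new or still open speak of the compounds shown alone.

Compounds measured so far:

Compound 1 `Cc1c(C(C)C)c(=O)on1C(=O)N1CCCCC1` gives 2 nM in an assay (strain Wistar) for inhibition of Hormone-sensitive lipase (Rattus norvegicus), read by spectrophotometry; a lower number here means a stronger inhibitor, a higher number a weaker inhibitor.
Compound 2 `Cc1c(C(C)C)c(=O)on1C(=O)N1CCCCC1C` gives 93 nM in this assay.

Among the measured compounds shown here, compound 1 stands lowest of the two numbers, and its only neighbour, compound 2, is a good deal higher. For the measured compounds named here, the single step between them, a 47-fold higher number from compound 1 to compound 2 (1.67 log units; beyond the scatter), is the only measured change on the saturated ring of the shared core, and it is large.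

Compound 3 `CCOC(=O)C1CCCN(C(=O)n2oc(=O)c(C(C)C)c2C)C1` carries a different change at a different place: ethoxycarbonyl in place of hydrogen on a saturated ring carbon. The measured step from compound 1 to compound 2 bears on it only loosely, since the position on the ring and the group both differ; the ring nitrogen is two ring bonds away here rather than one. Still, that step shows that a substituent on this ring can cost a great deal, and the ethoxycarbonyl group is larger than a methyl. Compound 3 is therefore expected to give a higher number in this assay than compound 1, an estimated step of a 20-fold higher number from compound 1 to compound 3 (1.30 log units; beyond the scatter), with wide uncertainty. The estimate for compound 3 is 40 nM, with a range from 5 nM to 300 nM.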

Compound 3, half-maximal inhibitory concentration: 28 nM
For compound 3 the middle estimate is 1.4-fold (0.15 log units) above the measured one; measured number inside the range.
By their numbers in this assay, from the lowest: compound 1; then compound 3; then compound 2.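

With ethoxycarbonyl in place of hydrogen on a saturated ring carbon, two ring bonds from the ring nitrogen, this assay shows a 14-fold higher number from compound 1 to compound 3 (1.15 log units; beyond the scatter). The earlier methyl change, a 47-fold higher number from compound 1 to compound 2 (1.67 log units; beyond the scatter), had given the only view of substitution on this ring, and the new step shows that a higher number is not confined to that one group and place, since both substituted compounds lie beyond the scatter from compound 1. No measurement given here accounts for the rise at this position or separates the contribution of the ethoxycarbonyl group from that of its place on the ring.

The compounds shown leave open whether the cost depends chiefly on the position or on the group, as methyl and ethoxycarbonyl are not compared at the same ring carbon. They also leave open how a carboxylic acid, an amine or a longer chain in place of hydrogen at this ring carbon would compare with compound 3, and whether any substituent here could keep the number as low as that of compound 1.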